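A few compounds are considered here, and "the series" means these few. Any claim that something is new, unique, unknown or untested is made for them only; others in the source may bear on it.

Measured so far in an assay (Populus sieboldii x Populus grandidentata) for inhibition of Trans-cinnamate 4-monooxygenase (Populus kitakamiensis), with a stated time of 60 min; a lower number here means a stronger inhibitor, a higher number a weaker inhibitor:
- compound 1, `Sc1nnc(-c2cccs2)o1`: 6200 nM
- compound 2, `Sc1nnc(-c2cccc(Cl)c2)o1`: 210 nM
- compound 3, `Fc1ccc(-c2nnc(S)o2)cc1`: 3300 nM

Compound 2 stands lowest of the three numbers in this assay. The nearest is compound 3, whose number is higher by a gap beyond the usual scatter; the furthest is compound 1, higher still, also beyond the scatter. Going by the values given here, no two of the measured compounds differ in only one place, so no single measured step isolates any one change.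

The next compound is compound 4, `COc1cccc(-c2nnc(S)o2)c1`. It differs from compound 2 in one place: methoxy in place of chloro on an aromatic carbon. Among the compounds with values here, nothing measured so far shows what this exchange does in this assay; the substituted six-membered rings of compound 2 and compound 3 carry different groups in different places, so their numbers cannot be read as a guide to this swap. The expectation is a step of moderate size toward a weaker inhibitor, with the direction uncertain enough that a number within the scatter of compound 2 would not surprise.

The step from compound 2 to compound 4 is estimated at a 2.9-fold higher number from compound 2 to compound 4 (0.46 log units; beyond the scatter). Compound 4 is accordingly expected to give 600 nM in this assay, with a range from 150 nM to 2500 nM.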

Compound 4, half-maximal inhibitory concentration: 6100 nM
Compound 4: middle estimate off by 10-fold (1.01 log units), on the low side, and the stated range ends below it.
By their numbers in this assay, from the lowest: compound 2; then compounds 3, 4 and 1 (each within the scatter of the next).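

In this assay, going by these compounds alone, the exchange of chloro for methoxy gives a 29-fold higher number from compound 2 to compound 4 (1.46 log units; beyond the scatter) and is the first change that can be read on its own, with the rest of the structure held constant. This aromatic carbon, meta to a group of 6 heavy atoms, therefore does not treat the two groups alike: the chloro compound carries the lower number, while the methoxy compound, with one more heavy atom and one hydrogen-bond acceptor that chloro lacks, carries the higher one. Nothing available accounts for the size of this step.

Still open, as far as these compounds go, is where other groups at this carbon would fall relative to chloro and methoxy, for example bromo, hydroxyl or an amine, and whether plain hydrogen there would give a number closer to that of the chloro compound or to that of the methoxy compound. Also open, from the compounds shown here alone, is whether the same exchange of chloro for methoxy on a different carbon of the six-membered ring would give a step of similar size.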